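Homologation of the oxazolidinedione side chain of compound 1

This account rests on a few compounds, and the source may have more. Where it says the series, first, only, none or still open, it means among the compounds named here.

compound 1 `CC(C)[C@@H](c1ccc(-c2ccc3cccc(F)c3c2)[nH]c1=O)[C@@H]1OC(=O)NC1=O`: 610 nM
compound 2 `CC(C)C(c1ccc(-c2ccc3cccc(F)c3c2)[nH]c1=O)C1NC(=O)NC1=O`: 320 nM

In a functional assay on CHO cells for antagonist activity at prostaglandin E2 receptor EP3 subtype (Homo sapiens), read by cAMP accumulation, with a stated time of 30 min (a higher number here means a weaker inhibitor, a lower number a stronger inhibitor), compound 1 gives 610 nM. Compound 2 gives 320 nM, and the two numbers lie within the usual scatter of each other, so neither compound stands apart. Compound 3 `CC(C)[C@H](C[C@H]1OC(=O)NC1=O)c1ccc(-c2ccc3cccc(F)c3c2)[nH]c1=O` has not been measured; it differs from compound 1 by (2,4-dioxo-1,3-oxazolidin-5-yl)methyl in place of 2,4-dioxo-1,3-oxazolidin-5-yl on a saturated chain carbon bound to an aromatic carbon and a saturated chain carbon. Going by the values given here, no measured pair shows a step of this kind, so the expectation rests on compound 1 alone. The change is expected to move the number in this assay by a modest amount, most likely toward weaker inhibition, as a 1.6-fold higher number from compound 1 to compound 3 (0.21 log units; within the scatter). Compound 3 is therefore estimated at 1000 nM, with a range of 250 nM to 4000 nM.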

Compound 3, half-maximal inhibitory concentration: 15 nM
The estimate for compound 3 lay 67-fold (1.82 log units) above the measured number; measured number outside the range, below it.
By their numbers in this assay, from the lowest: compound 3; then compounds 2 and 1 (each within the scatter of the next).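

In this assay, (2,4-dioxo-1,3-oxazolidin-5-yl)methyl in place of 2,4-dioxo-1,3-oxazolidin-5-yl gives a 41-fold lower number from compound 1 to compound 3 (1.61 log units; beyond the scatter), a large step. Going by these compounds alone, it shows that the number at this saturated chain carbon is highly sensitive to this single change, which the earlier compounds could not reveal. No measurement shown accounts for the size of this step.

Still open, on these data alone, is whether a longer chain carrying the same ring would extend the gain or lose it. As far as these compounds go, it is equally open whether a carboxylic acid could stand in for the ring at the end of the chain.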